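The source may hold more compounds than are shown below. What is called first, only, known or untested is meant among the compounds shown, and "the series" means these compounds.

Compound 1 `CC[C@@H](CCn1cncn1)c1ccccc1` is the parent of the set. In an ADME assay on RD cells (Homo sapiens) for cytotoxicity, read by MTT assay, with a stated time of 3 days (a lower number here means that less compound is tolerated, a higher number that more compound is tolerated), compound 1 gives 91.2 ug/mL. Compound 2 `CC[C@@H](CCn1cncn1)c1ccc(C)cc1` carries the change (methyl in place of hydrogen on an aromatic carbon); in this assay compound 2 gives 79.4 ug/mL, so the step is a 1.1-fold lower number from compound 1 to compound 2 (0.06 log units; within the scatter).

Compound 3 `c1ccc(C[C@H](CCn2cncn2)c2ccccc2)cc1` has a different core; how the core of compound 3 differs from the core of compound 1 is not broken down here. In this assay compound 3 gives 55.4 ug/mL, a value that sits within the scatter of both compound 1 and compound 2, so no order among the three can be read from these numbers.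

Compound 4 `Cc1ccc(C[C@H](CCn2cncn2)c2ccccc2)cc1` is not yet measured. It differs from compound 3 by methyl in place of hydrogen on an aromatic carbon, the same change as from compound 1 to compound 2, with the place described in the same words. Since that earlier step was a 1.1-fold lower number from compound 1 to compound 2 (0.06 log units; within the scatter), the step from compound 3 to compound 4 is expected to be of like size, a 1.1-fold lower number from compound 3 to compound 4 (0.04 log units; within the scatter), resting on a single precedent. In this assay compound 4 is therefore estimated at 50 ug/mL, with a range of 28 ug/mL to 90 ug/mL.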

Compound 4, half-maximal cytotoxic concentration: 37.8 ug/mL
Beside the measured number, compound 4's estimate is 1.3-fold (0.12 log units) above it; measured number inside the range.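

In this assay, methyl in place of hydrogen on an aromatic carbon gives a 1.5-fold lower number from compound 3 to compound 4 (0.17 log units; within the scatter), so on this second core the step again stays inside the usual variation between repeat measurements. Set beside the earlier step, the change shows no measurable dependence on the core, and the two results agree: the same change on two cores in this assay, a 1.1-fold lower number (0.06 log units; within the scatter) from compound 1 to compound 2 and a 1.5-fold lower number (0.17 log units; within the scatter) from compound 3 to compound 4, 1.3-fold (0.11 log units) apart, within the scatter of two such steps. This supports carrying the methyl change between these two cores only as a change with no readable effect on either; it does not show that methyl shifts tolerance, and two small steps cannot show that a change of real size would carry over in the same way.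

Open, going by these compounds, is whether a different group at this place, such as a chlorine atom, a methoxy group, an amine or a carboxylic acid, would give a step beyond the scatter on either core. Also open, on these data alone, is whether the methyl step would hold on a core with a longer chain.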